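The source may report more compounds than this note shows. Statements on the series, on what has been measured and on what is new or still open speak of the compounds shown alone.

Compound 1 (`CCOC(=O)c1c(-c2ccccc2)[nH]c2cc(OC)ccc2c1=O`) is the starting point here. In an ADME assay on Raji cells (Homo sapiens) for cytotoxicity, read by luminescence, with a stated time of 72 h (on this read-out lower numbers stand for an effect already at smaller amounts and higher numbers for an effect only at larger amounts of compound), compound 1 gives > 21500 nM as a limit of the assay and not a number. Compound 2 (`CCOC(=O)c1c(-c2cccc(C)c2)[nH]c2cc(OC)ccc2c1=O`) gives > 21500 nM as a limit too. Compound 3 (`CCOC(=O)c1c(-c2cccc(-c3ccccc3)c2)[nH]c2cc(OC)ccc2c1=O`) likewise gives > 21500 nM as a limit. Compound 1 therefore stands with the other two at the limit of > 21500 nM in this assay, at which 3 of the 3 values shown sit, and nothing ranks the three against each other.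

Compound 4 (`CCOC(=O)c1c(-c2cccc(OC)c2)[nH]c2cc(OC)ccc2c1=O`) has not yet been measured. It differs from compound 1 by methoxy in place of hydrogen on an aromatic carbon, meta to a large group, and the count of that change reads methoxy in place of hydrogen on an aromatic carbon in full.

Two measured changes come closest. They also replace hydrogen on an aromatic carbon: a step that the two limits leave unreadable from compound 1 to compound 2 with methyl entering and a step that the two limits leave unreadable from compound 1 to compound 3 with phenyl entering. Neither has a size that can be read, so they give no sign of any change in this assay and no direction for one. The expected step is a step that the limit leaves unreadable from compound 1 to compound 4 with no direction claimed.

For compound 4 the expected value is 25000 nM with an estimated range from 11000 nM to 50000 nM and the likeliest report is another limit rather than a number.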

Compound 4, half-maximal effective concentration: > 21500 nM
Compound 4 ended at the assay's limit; the forecaster's own chance of this, stated with the estimate: 85%; the middle value does not contradict the limit.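

No new step can be read from compound 4, because compound 1, compound 2, compound 3 and compound 4 all give a limit of the assay and not a number: the limit of > 21500 nM in this assay, at which 4 of the 4 values shown sit.

The compounds shown leave open whether any group in place of hydrogen on this aromatic ring would give a readable number in this assay and how these four compounds truly rank.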